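The compounds below may be only part of what the source reports. "The series", "measured", "known", "first", "only" and "open" are said of these compounds alone.

Measured compounds:
Compound 1, `COCCOc1nc(N)nc2c1ncn2/C=C1/CC1(CO)CO`. In an ADME assay on MOLT-3 cells (Homo sapiens) for cytotoxicity, with a stated time of 7 days (a higher number here means that more compound is tolerated, a lower number that less compound is tolerated), compound 1 gives > 20000 nM, which is a limit of the assay.
Compound 2, `CCCCCCCCOc1nc(N)nc2c1ncn2/C=C1/CC1(CO)CO`. In this assay compound 2 gives > 20000 nM, again a limit of the assay.
Compound 3, `Nc1nc(OCc2ccccc2)c2ncn(/C=C3/CC3(CO)CO)c2n1`. In this assay compound 3 gives > 20000 nM, also a limit of the assay.

Compound 2 therefore stands at the limit of > 20000 nM in this assay, at which 3 of the 3 values shown sit, and no number is known for it. Among the compounds with values here, none of the measured steps can be read: a step that the two limits leave unreadable from compound 1 to compound 2, a step that the two limits leave unreadable from compound 1 to compound 3 and a step that the two limits leave unreadable from compound 2 to compound 3 all end at limits on both sides. The change to compound 4, `CCCCOc1nc(N)nc2c1ncn2/C=C1/CC1(CO)CO`, is hydrogen in place of butyl on a saturated chain carbon, four bonds along the chain from an oxygen on an aromatic ring. The unreadable steps that change the chain give no guide, so no step beyond the scatter is expected for a number no higher from compound 2 to compound 4 (the limit leaves the size open). Compound 4 is expected to give 20000 nM, in the range 10000 nM to 40000 nM.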

Compound 4, half-maximal cytotoxic concentration: > 20000 nM
Compound 4: a limit, no number; the forecaster's own chance of this, stated with the estimate: 80%; the middle value sits exactly at the limit.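

Compound 4 also ends at a limit, so its steps from compound 1, compound 2 and compound 3 cannot be read: the limit of > 20000 nM in this assay, at which 4 of the 4 values shown sit. The compounds shown leave open what number any of them would give in this assay, and whether changing the group on the oxygen alters it.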